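The source may report more compounds than this note shows. Statements on the series, on what has been measured and on what is new or still open speak of the compounds shown alone.

Compound 1 `NC(=S)N1CCCc2c(OCCCCCOc3cccc4ccccc34)cccc21` gives > 50000 nM in an ADME assay on Huh-7 cells (Homo sapiens) for cytotoxicity (a lower number here means that less compound is tolerated, a higher number that more compound is tolerated), which is a limit of the assay rather than a number.
Compound 2 `O=C(NC(=S)N1CCc2c(OCCCCCOc3ccc(Cl)cc3)cccc21)c1ccc(Cl)cc1` gives 21700 nM in this assay.
Compound 3 `O=C(NC(=S)N1CCc2c(OCCCCCOc3ccc(Cl)cc3)cccc21)c1ccc(C(F)(F)F)cc1` gives 32700 nM in this assay.

Of the two numbers shown, those for compound 2 and compound 3 lie within the scatter of each other, as the step of a 1.5-fold higher number from compound 2 to compound 3 (0.18 log units; within the scatter) shows, so no order between them can be read. Within the data shown here, the one remaining value, that of compound 1, is a limit (the limit of > 50000 nM in this assay, at which 1 of the 3 values shown sits).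

Compound 4 `O=C(NC(=S)N1CCc2c(OCCCCCOc3ccc(Cl)cc3)cccc21)C1CCCC1` has not yet been measured. It differs from compound 3 in one place: cyclopentyl in place of 4-(trifluoromethyl)phenyl on a carbonyl carbon. Among the measured compounds shown here, the only measured step, a 1.5-fold higher number from compound 2 to compound 3 (0.18 log units; within the scatter), exchanges one substituent on an aromatic carbon for another and stays within the scatter; no measured step exchanges an aromatic ring for a non-aromatic one on the carbonyl carbon, so it offers no direct guide. With nothing pointing either way, compound 4 is expected to stay near compound 3, a step of a 1.1-fold lower number from compound 3 to compound 4 (0.04 log units; within the scatter) in this assay no larger than the scatter. Compound 4 is therefore estimated at 30000 nM, within 12000 nM to 80000 nM.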

Compound 4, half-maximal cytotoxic concentration: > 50000 nM
Compound 4: only a limit was reported (the forecaster's own chance of this, stated with the estimate: 30%); middle value at least 1.6-fold (0.22 log units) from the limit.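

Compound 4 reports only a limit: the limit of > 50000 nM in this assay, at which 2 of the 4 values shown sit. The earlier compounds shown here exchanged only a substituent on an aromatic ring, whereas here the aromatic ring on the carbonyl carbon itself gives way to non-aromatic cyclopentyl, and the number in this assay does not drop. Measured against the 4-chlorophenyl partner, this change gives an at least 2.3-fold higher number from compound 2 to compound 4 (0.36 log units; beyond the scatter), while against the 4-(trifluoromethyl)phenyl partner it gives an at least 1.5-fold higher number from compound 3 to compound 4 (0.18 log units; that floor lies within the scatter), so only the first comparison supports an order.

The compounds shown leave open how far past the limit the true value of compound 4 lies. They also leave open whether a straight alkyl chain, cyclopropyl or a piperidine ring on the same carbonyl carbon would behave like cyclopentyl.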